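Cyclopentyl for 1-hydroxy-1-methylethyl: stability notes

A few compounds are considered here, and "the series" means these few. Any claim that something is new, unique, unknown or untested is made for them only; others in the source may bear on it.

- compound 1 (`COc1cc(-c2cnn3cc(OC)c(C(C)(C)O)nc23)ccn1`) in an ADME assay on microsomes from liver (Homo sapiens) for metabolic stability, with a stated time of 60 min, tested at 1 uM (on this read-out lower numbers stand for a less stable compound and higher numbers for a more stable compound), gives 66%
- compound 2 (`Cn1cc(-c2nc3c(-c4ccnc(OC5CC5)c4)cnn3cc2OCC(C)(C)O)cn1`) in this assay gives 53%

Compound 1 stands highest of the two numbers, and the gap down to compound 2 lies beyond the usual scatter. For the measured compounds named here, these two compounds differ in more than one place, so no single-change step is available to read across.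

The next compound is compound 3 (`COc1cc(-c2cnn3cc(OC)c(C4CCCC4)nc23)ccn1`), which shares the core of compound 1 and carries one change (cyclopentyl in place of 1-hydroxy-1-methylethyl on an aromatic carbon). This places cyclopentyl in place of 1-hydroxy-1-methylethyl on an aromatic carbon, ortho to a methoxy group.

Going by the values given here, no measured pair in this assay tests this change, so the expectation is a judgement with a wide range. A fall beyond the scatter is expected, taking compound 1 at 66% as the starting point. The estimated change is a number 36 percentage points lower from compound 1 to compound 3 (beyond the scatter) in this read-out. Compound 3 is expected at 30% in this assay with an estimated range from 10% to 55% as its limits of expectation.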

Compound 3, percent of the compound remaining: 32%
Beside the measured number, compound 3's estimate is 2 percentage points below it, and the stated range covers the measured number.
By their numbers in this assay, from the lowest: compound 3; then compound 2; then compound 1.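

In this assay, for the compounds shown here, placing cyclopentyl in place of 1-hydroxy-1-methylethyl on the aromatic carbon ortho to a methoxy group gives a number 34 percentage points lower from compound 1 to compound 3 (beyond the scatter) and provides the first single-change step. The read-out at this position therefore depends on the group it carries, and this change moves the compound towards the less stable end of the scale, with compound 3 now the lowest of the three compounds. The change replaces an open group holding one hydrogen-bond donor and one hydrogen-bond acceptor with a carbon-only five-membered ring, but no measurement shown here explains the fall, so the step records an outcome and not a cause.

On these data alone, a single step cannot separate the loss of the hydroxyl from the arrival of the ring, so it remains open whether a tert-butyl group, or a 1-hydroxycyclopentyl group that holds both the ring and the hydroxyl, would read closer to compound 1 or to compound 3. As far as these compounds go, whether a basic amine such as aminomethyl at this position would hold up in this assay also remains open, as does the size of this step on any other core.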